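From pentan-3-yl to cyclopentyl: a permeability note

A few compounds are considered here, and "the series" means these few. Any claim that something is new, unique, unknown or untested is made for them only; others in the source may bear on it.

Of the compounds shown here, three have numbers so far in an ADME assay on MDCK-II cells (Canis lupus familiaris) for permeability; on this read-out lower numbers stand for lower permeability and higher numbers for higher permeability. Compound 1 `CC(C)Oc1cc(Oc2cnc(C(=O)N(C)C)nc2)cc(-c2nccc(=O)[nH]2)c1` gives 7.1 10^-6 cm/s, compound 2 `CCS(=O)(=O)c1ccc(Oc2cc(O[C@@H](C)CO)cc(-c3nccc(=O)[nH]3)c2)cc1` gives 2.8 10^-6 cm/s, and compound 3 `CCC(CC)Oc1cc(Oc2cnc(C(=O)N(C)C)nc2)cc(-c2nccc(=O)[nH]2)c1` gives 17 10^-6 cm/s. Compound 3 is the highest of the three, and its gaps to compound 1 and compound 2 both lie beyond the scatter.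

Compound 4 `CN(C)C(=O)c1ncc(Oc2cc(OC3CCCC3)cc(-c3nccc(=O)[nH]3)c2)cn1` has cyclopentyl in place of the pentan-3-yl of compound 3, on an oxygen on an aromatic ring: cyclopentyl in place of pentan-3-yl on an oxygen on an aromatic ring. Among the compounds with values here, only one measured step bears on this change: a 2.4-fold higher number from compound 1 to compound 3 (0.38 log units; beyond the scatter), with pentan-3-yl in place of isopropyl on an oxygen on an aromatic ring. That step is modest, and it involves two open-chain groups. Within the data shown here, no measured compound carries a ring at this oxygen, so the data do not show what closing the ring does. Compound 2 differs from compound 3 in more than one place and offers no direct guide.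

A small downward step in this assay is expected, probably no larger than the scatter. The estimated step is a 1.3-fold lower number from compound 3 to compound 4 (0.12 log units; within the scatter). For compound 4 the expected value is 13 10^-6 cm/s, with an estimated range of 7 10^-6 cm/s to 25 10^-6 cm/s.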

Compound 4, apparent permeability in the MDCK-II assay: 14 10^-6 cm/s
Estimate against measurement, compound 4: 1.1-fold (0.03 log units) below; the range from low to high includes it.
By their numbers in the MDCK-II assay, from the lowest: compound 2; then compounds 1, 4 and 3 (each within the scatter of the next, the first and the last beyond it).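

Working notes on the oxygen substituent: in the MDCK-II assay compound 4 gives 14 10^-6 cm/s. With cyclopentyl, a ring of carbon only now stands at this oxygen on an aromatic ring, and in the MDCK-II assay closing the chain of five carbons gives a 1.2-fold lower number from compound 3 to compound 4 (0.08 log units; within the scatter), so the read-out does not separate the ring from the open pentan-3-yl. Measured against isopropyl, the same ring gives a 2.0-fold higher number from compound 1 to compound 4 (0.29 log units; within the scatter), which lies within the scatter, whereas the open chain gave a 2.4-fold higher number from compound 1 to compound 3 (0.38 log units; beyond the scatter), which lies beyond it; the gain seen with pentan-3-yl is therefore not confirmed for cyclopentyl, although the two groups themselves cannot be told apart. In a physicochemical assay for lipophilicity, using the shake flask method (a lower number here means a more polar compound, a higher number a more lipophilic compound), compound 3 gives 1.91 and compound 4 gives 1.74. In the physicochemical assay the change from pentan-3-yl to cyclopentyl gives a number 0.17 log units lower from compound 3 to compound 4 (within the scatter), and no measurement at hand accounts for the readings in either assay.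

Open at this oxygen is how a six-membered ring such as cyclohexyl, a smaller ring such as cyclopropyl, or a ring holding an oxygen such as tetrahydropyranyl would read. Also open, as far as these compounds go, is whether a ring carrying an amine or a carboxylic acid would stay on the same level in the MDCK-II assay.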